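A few compounds are considered here, and "the series" means these few. Any claim that something is new, unique, unknown or untested is made for them only; others in the source may bear on it.

The work sets two cores side by side. Compound 1 `Cc1ccc(-n2nc(C(=O)Nc3ccc(Oc4ncnc5ccsc45)c(F)c3)c(C)cc2=O)cc1` gives 17300 nM in a functional assay on HepG2 cells (Homo sapiens) for cytotoxicity, read by MTT assay, with a stated time of 72 h (on this read-out higher numbers stand for weaker inhibition and lower numbers for stronger inhibition), and compound 2 `Cc1cc(=O)n(-c2ccc(F)cc2)nc1C(=O)Nc1ccc(Oc2ncnc3ccsc23)c(F)c1` gives 470 nM. The step of a 37-fold lower number from compound 1 to compound 2 (1.57 log units; beyond the scatter) comes from the change (fluoro in place of methyl on an aromatic carbon). Compound 3 `Cc1ccc(-n2nc(C(=O)Nc3ccc(Oc4ncnc5sccc45)cc3)c(C)cc2=O)cc1` gives in this assay only > 40000 nM, which is a limit of the assay and not a number; it is the limit of > 40000 nM in this assay, at which 1 of the 3 values shown sits. The difference between the core of compound 1 and the core of compound 3 is not broken down here. Compound 4 `Cc1cc(=O)n(-c2ccc(F)cc2)nc1C(=O)Nc1ccc(Oc2ncnc3sccc23)cc1` awaits measurement in this assay; it differs from compound 3 by fluoro in place of methyl on an aromatic carbon, the same change as between compound 1 and compound 2, at the same place. The expected step is an at least 20-fold lower number from compound 3 to compound 4 (1.30 log units; beyond the scatter). This expectation rests on the measured step of a 37-fold lower number from compound 1 to compound 2 (1.57 log units; beyond the scatter), while the limit for compound 3 leaves the starting point open. Compound 4 is estimated at 2000 nM, within 400 nM to 20000 nM.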

Compound 4, half-maximal inhibitory concentration: 6460 nM
For compound 4 the middle estimate is 3.2-fold (0.51 log units) below the measured one; low and high end bracket the measured number.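

In this assay, the change from 4-methylphenyl to 4-fluorophenyl carries over to the second core in the same direction, with an at least 6.1-fold lower number from compound 3 to compound 4 (0.79 log units; beyond the scatter). Set side by side, the two steps read as follows: the same change on two cores in this assay, a 37-fold lower number (1.57 log units; beyond the scatter) from compound 1 to compound 2 and an at least 6.1-fold lower number (0.79 log units; beyond the scatter) from compound 3 to compound 4; the limit leaves it open whether they differ. Compound 3 stands at a limit of the assay and not at a number, so the two cores show a shared direction but not a shared size: the limit of > 40000 nM in this assay, at which 1 of the 4 values shown sits.

The compounds shown carry only methyl or fluoro at this place, so it remains open how a chloro, a methoxy or an amine there would read. On these data alone, it also remains open whether the same change would give a lower number on any further core.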